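The source may report more compounds than this note shows. Statements on the series, on what has been measured and on what is new or still open speak of the compounds shown alone.

Measured compounds and their values:
compound 1, `CC(=O)c1c(NNc2ccccc2)cc(C)oc1=O`, 55.6%
compound 2, `CC(=O)c1c(NNc2ccc(Cl)cc2)cc(C)oc1=O`, 58.6%
compound 3, `COc1ccc(NNc2cc(C)oc(=O)c2C(C)=O)cc1`, 44.4%

All three were read in a functional assay on the whole organism for inhibition, with Rattus norvegicus as the target, read by paw edema, with a stated time of 3 h, at a dose of 50 mg/kg; on this read-out lower numbers stand for less inhibition and higher numbers for more inhibition at the one dose given (going by the name of the read-out). Compound 3 stands lowest of the three numbers: its nearest neighbour is compound 1, and the step of a number 11.2 percentage points lower from compound 1 to compound 3 (beyond the scatter) lies beyond the scatter, as does the larger step of a number 14.2 percentage points lower from compound 2 to compound 3 (beyond the scatter). Between compound 1 and compound 2 the step of a number 3 percentage points higher from compound 1 to compound 2 (within the scatter) is within the scatter, so no order between those two is claimed.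

Compound 4, `CC(=O)c1c(NNc2ccc([N+](=O)[O-])cc2)cc(C)oc1=O`, is not yet measured. It differs from compound 3 in one place: nitro in place of methoxy on an aromatic carbon. Going by the values given here, no measured step exchanges methoxy for nitro, so the expectation can rest only on what the methoxy did. Both steps that introduced methoxy lowered the number beyond the scatter, a number 11.2 percentage points lower from compound 1 to compound 3 (beyond the scatter) and a number 14.2 percentage points lower from compound 2 to compound 3 (beyond the scatter), while the chloro step a number 3 percentage points higher from compound 1 to compound 2 (within the scatter) changed little. As far as these compounds go, removing the methoxy is therefore expected to bring the number back toward the level of compound 1 and compound 2, though the nitro group itself is untested here and the range is kept wide.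

Compound 4 is estimated at 54%, within 40% to 68%, which means an expected step of a number 9.6 percentage points higher from compound 3 to compound 4 (within the scatter).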

Compound 4, a percentage reported as inhibition, in the whole organism at one dose (the size of the read-out at that dose, not a potency): 45.5%
Estimate against measurement, compound 4: 8.5 percentage points above; the range from low to high includes it.
By their numbers in this assay, from the lowest: compounds 3 and 4 (each within the scatter of the next); then compounds 1 and 2 (each within the scatter of the next).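

In this assay, the exchange of methoxy for nitro gave a number 1.1 percentage points higher from compound 3 to compound 4 (within the scatter) and so did not separate the two groups at this place, on an aromatic carbon para to a large group. Nitro also gave a number 10.1 percentage points lower from compound 1 to compound 4 (beyond the scatter) and a number 13.1 percentage points lower from compound 2 to compound 4 (beyond the scatter) and thus stood beyond the scatter on the low side of both the hydrogen and the chloro compounds, which shows that among these four compounds the lower level is not confined to methoxy, while chloro in compound 2 goes against any rule that a substituent here lowers the number. The data offer no measured basis for explaining why nitro and methoxy fall together while chloro stays with hydrogen.

As far as these compounds go, it remains open whether an amine, a carboxylic acid or a longer chain at this place would fall with methoxy and nitro or stay with hydrogen and chloro. The compounds shown also leave open whether the same grouping would hold at any other dose or time, since each number is a single reading at one dose.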